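This account rests on a few compounds, and the source may have more. Where it says the series, first, only, none or still open, it means among the compounds named here.

Measured so far in a functional assay on A549 cells (Homo sapiens) for cytotoxicity, read by MTT assay, with a stated time of 72 h; on this read-out higher numbers stand for weaker inhibition and lower numbers for stronger inhibition:

- compound 1, `O=C(Nc1ccc(Oc2ccnc3[nH]ccc23)cc1)c1nn(-c2ccccc2)ccc1=O`: 10500 nM
- compound 2, `O=C(Nc1ccc(Oc2ccnc3[nH]ccc23)cc1)c1nn(-c2ccc(Br)cc2F)ccc1=O`: 26100 nM
- compound 3, `O=C(Nc1ccc(Oc2ccnc3[nH]ccc23)c(F)c1)c1nn(-c2ccccc2)ccc1=O`: 56800 nM

Compound 3 stands with the highest number of the three, its steps to compound 1 and compound 2 both lying beyond the scatter. The change from compound 1 to compound 2 is 4-bromo-2-fluorophenyl in place of phenyl on an aromatic nitrogen; it produced a 2.5-fold higher number from compound 1 to compound 2 (0.40 log units; beyond the scatter). The cores of compound 1 and compound 3 differ by fluoro in place of hydrogen on an aromatic carbon, which produced a 5.4-fold higher number from compound 1 to compound 3 (0.73 log units; beyond the scatter).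

Compound 4, `O=C(Nc1ccc(Oc2ccnc3[nH]ccc23)c(F)c1)c1nn(-c2ccc(Br)cc2F)ccc1=O`, is not yet measured. It differs from compound 3 by 4-bromo-2-fluorophenyl in place of phenyl on an aromatic nitrogen, the same change as from compound 1 to compound 2, and the surroundings of the place are described in the same words for both pairs. Only that one earlier occurrence is available to rest on. The step from compound 3 to compound 4 is expected to be a 2.5-fold higher number from compound 3 to compound 4 (0.39 log units; beyond the scatter), because compound 1 to compound 2 gave a 2.5-fold higher number from compound 1 to compound 2 (0.40 log units; beyond the scatter). For compound 4 the estimate is 140000 nM, expected to fall between 55000 nM and 350000 nM; a number this high may be reported only as a limit.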

Compound 4, half-maximal inhibitory concentration: 55700 nM
Compound 4: middle estimate off by 2.5-fold (0.40 log units), on the high side; the measured number falls inside the stated range.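

In this assay, 4-bromo-2-fluorophenyl in place of phenyl on an aromatic nitrogen gave a 1.0-fold lower number from compound 3 to compound 4 (0.01 log units; within the scatter), and the two occurrences of this change cannot be told apart: the same change on two cores in this assay, a 2.5-fold higher number (0.40 log units; beyond the scatter) from compound 1 to compound 2 and a 1.0-fold lower number (0.01 log units; within the scatter) from compound 3 to compound 4, 2.5-fold (0.40 log units) apart, within the scatter of two such steps

Fluoro in place of hydrogen on an aromatic carbon gave a 2.1-fold higher number from compound 2 to compound 4 (0.33 log units; beyond the scatter), in the same direction on both cores, and these two steps also cannot be told apart: the same change on two cores in this assay, a 5.4-fold higher number (0.73 log units; beyond the scatter) from compound 1 to compound 3 and a 2.1-fold higher number (0.33 log units; beyond the scatter) from compound 2 to compound 4, 2.5-fold (0.40 log units) apart, within the scatter of two such steps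

This shows no measurable dependence of either change on the core, but it does not show that the steps carry over unchanged, since each change has only two occurrences and the aryl step lies beyond the scatter on one core and within it on the other.

The compounds shown hold only phenyl or 4-bromo-2-fluorophenyl on the aromatic nitrogen, and only hydrogen or fluoro on the aromatic carbon. On these data alone, how an amine, a carboxylic acid or a longer chain would read in either place remains open, as does whether any of these steps holds outside this cytotoxicity read-out.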